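Compound 2 to compound 3: ring opened to 1,3-disulfanylpropyl

The source may report more compounds than this note shows. Statements on the series, on what has been measured and on what is new or still open speak of the compounds shown alone.

Two compounds of the series have been run in a functional assay on HO8910 cells (Homo sapiens) for inhibition, read by MTT assay, with a stated time of 24 h, tested at 1 ug/mL; a higher number here means more inhibition of growth at the concentration tested, a lower number less inhibition of growth. Compound 1 `O=C(CCCCC1CCSS1)Nc1ccccn1` is recorded in this assay as "not active" (no number reported), with no figure given. For the measured compounds named here, compound 2 `O=C(CCCCC1CCSS1)Nc1ccc(Cl)cn1` gives 2.1% in this assay, and this is the only number in hand, so compound 2 stands alone on the scale and cannot be ranked against compound 1 beyond the note that both show little growth inhibition. Going by the values given here, no step between measured compounds is available. Compound 3 `O=C(CCCCC(S)CCS)Nc1ccc(Cl)cn1` differs from compound 2 by a group of 5 heavy atoms (3 carbon, 2 sulfur; no ring) in place of a group of 5 heavy atoms (3 carbon, 2 sulfur; one five-membered non-aromatic ring with 2 hetero atoms), on a saturated chain carbon, four bonds along the chain from a carbonyl carbon. Among the compounds with values here, with no step to lean on, the expectation is for compound 3 to stay near compound 2, a change not beyond the usual scatter, as the expected step of a number 1.9 percentage points higher from compound 2 to compound 3 (within the scatter) expresses. Compound 3 is therefore estimated at 4% in this assay, within a range from -8% to 16%, because compound 2 itself gives only 2.1%.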

Compound 3, percent growth inhibition at one concentration: "not active" (no number reported)
Compound 3: no number reported; no gap can be computed for the estimate.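

For the compounds shown here, with compound 3 carrying no number in this assay, no step from compound 2 to compound 3 can be read. The compounds shown leave open whether opening the ring to 1,3-disulfanylpropyl shifts growth inhibition at all. No evidence in hand bears on this result.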